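The source may report more compounds than this note shows. Statements on the series, on what has been measured and on what is new or still open speak of the compounds shown alone.

For the measured compounds named here, compound 2 `CC(F)(F)c1cccc(N2C(=O)CSC2c2cccc(C(=O)NCCCCc3ccccc3)c2)c1` gives the lower of the two numbers so far: in a functional assay on 143B cells (Homo sapiens) for inhibition, read by CCK-8 assay, with a stated time of 72 h, tested at 1 uM (on this read-out higher numbers stand for more inhibition at the one concentration tested (going by the name of the read-out) and lower numbers for less inhibition), compound 2 gives 1%, while compound 1 `COc1cccc(OC)c1N1C(=O)CSC1c1cccc(C(=O)NCCCCc2ccccc2)c1` gives 31%. Compound 3 `COc1ccc(N2C(=O)CSC2c2cccc(C(=O)NCCCCc3ccccc3)c2)c(OC)c1` differs from compound 2 by a group of 10 heavy atoms (8 carbon, 2 oxygen; one six-membered aromatic ring of carbon only) in place of a group of 10 heavy atoms (8 carbon, 2 fluorine; one six-membered aromatic ring of carbon only), on an amide-type nitrogen in a ring. Going by the values given here, the one step that bears on this is a number 30 percentage points lower from compound 1 to compound 2 (beyond the scatter), which runs the other way with a related group of 10 heavy atoms (8 carbon, 2 oxygen) rather than the 2,4-dimethoxyphenyl itself, so the expected step is a number 24 percentage points higher from compound 2 to compound 3 (beyond the scatter), upward. Compound 3 is therefore expected to give 25%, between 5% and 45%.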

Compound 3, a percentage reported as inhibition, at one concentration (the size of the read-out at that concentration, not a potency): 53%
The estimate for compound 3 lay 28 percentage points below the measured number; the whole stated range lies below it.
By their numbers in this assay, from the lowest: compound 2; then compound 1; then compound 3.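

Putting 2,4-dimethoxyphenyl in place of the fluorinated group on the amide-type nitrogen in the ring gives a number 52 percentage points higher from compound 2 to compound 3 (beyond the scatter) in this assay, a large step at this position. Putting 2,4-dimethoxyphenyl in place of 2,6-dimethoxyphenyl gives a number 22 percentage points higher from compound 1 to compound 3 (beyond the scatter), so the read-out here depends on how the two methoxy groups are arranged on the ring, not only on their presence. Nothing available explains either step.

On these data alone, whether a single methoxy group would hold this level of inhibition remains open. So does the effect of an amine or a carboxylic acid on this phenyl ring.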